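The source may hold more compounds than are shown below. What is called first, only, known or untested is meant among the compounds shown, and "the series" means these compounds.

Measured in a functional assay on U-251 cells (Homo sapiens) for antiproliferative activity, read by MTT assay, with a stated time of 48 h; on this read-out lower numbers stand for stronger inhibition and higher numbers for weaker inhibition:

- Compound 1 `COc1ccc(-c2nc3cccc(-c4cc(OC)c(OC)c(OC)c4)c3o2)cc1OC`: 1300 nM
- Compound 2 `COc1cc(-c2cccc3nc(-c4ccc(Br)cc4)oc23)cc(OC)c1OC`: > 25000 nM, a limit of the assay and not a number

Compound 2 has no exact value and stands only at the limit of > 25000 nM in this assay, at which 1 of the 2 values shown sits.

Compound 3 `COc1cc(-c2cccc3nc(-c4cccc(N)c4)oc23)cc(OC)c1OC` has not yet been measured. It carries 3-aminophenyl in place of 4-bromophenyl on an aromatic carbon of a five-membered aromatic ring with 1 nitrogen and 1 oxygen: 3-aminophenyl in place of 4-bromophenyl on an aromatic carbon.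

For the measured compounds named here, one measured step bears on this change, and it concerns the same place. That step is an at least 19-fold higher number from compound 1 to compound 2 (1.28 log units; beyond the scatter), which is large and beyond the scatter, and it brought in the 4-bromophenyl group in place of 3,4-dimethoxyphenyl. Compound 3 also lacks the 4-bromophenyl group, so a sizeable move to a lower number is expected in this assay. Going by the values given here, no measured compound carries 3-aminophenyl, however, so the size of the recovery is uncertain, and a second limit remains possible.

The expected change is an at least 5.0-fold lower number from compound 2 to compound 3 (0.69 log units; beyond the scatter). For compound 3 the estimated value is 5000 nM, with an expected range from 900 nM to 25000 nM.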

Compound 3, half-maximal inhibitory concentration: 2200 nM
The estimate for compound 3 lay 2.3-fold (0.36 log units) above the measured number; the range from low to high includes it.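

In this assay, for the compounds shown here, 3,4-dimethoxyphenyl turns out not to be the only group at this place on the five-membered ring that goes with a measurable value, since the step reads a 1.7-fold higher number from compound 1 to compound 3 (0.23 log units; within the scatter). Replacing 4-bromophenyl with 3-aminophenyl gives an at least 11-fold lower number from compound 2 to compound 3 (1.05 log units; beyond the scatter), so the large step seen earlier does not extend to every replacement of 3,4-dimethoxyphenyl, and among the three compounds shown only compound 2 goes against a measurable value. Compound 2 has no exact value, only a limit of the assay, so the true size of this step remains unknown: the limit of > 25000 nM in this assay, at which 1 of the 3 values shown sits.

The compounds shown do not separate the identity of the substituent on the phenyl ring from where it sits, as 4-aminophenyl and 3-bromophenyl would be needed to tell those two apart. On these data alone, it also remains open how an unsubstituted phenyl or a phenyl carrying a carboxylic acid would read at this place, and whether the amine of compound 3 can be replaced by a hydroxyl or a methoxy group.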